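The source may report more compounds than this note shows. Statements on the series, on what has been measured and on what is new or still open speak of the compounds shown alone.

In a functional assay on Bel-7402 cells (Homo sapiens) for cytotoxicity, read by MTT assay, with a stated time of 48 h (a lower number here means a stronger inhibitor, a higher number a weaker inhibitor), compound 1 `COc1ccc(-c2cn(C(=O)Nc3cc(OC)c(OC)c(OC)c3)c(=O)n2-c2cc(OC)c(OC)c(OC)c2)cc1` gives > 50000 nM, which is a limit of the assay rather than a number. Compound 2 `COc1cc(-n2c(-c3ccccc3)cn(C(C)=O)c2=O)cc(OC)c1OC` likewise gives > 50000 nM in this assay, again only a limit. Compound 3 `COc1cc(-n2c(-c3ccc(Cl)cc3)cn(C(C)=O)c2=O)cc(OC)c1OC` is reported as "not determined" (no result reported) in this assay, so it stands without a number of its own among the values shown. Compound 4 `COc1cc(-n2c(-c3ccc(F)cc3F)cn(C(C)=O)c2=O)cc(OC)c1OC` differs from compound 3 by 2,4-difluorophenyl in place of 4-chlorophenyl on an aromatic carbon. For the measured compounds named here, no step between two measured compounds is available, and one expects no step beyond the usual scatter in this assay, in either direction, since compound 1 and compound 2 both sit at the limit of > 50000 nM in this assay, at which 2 of the 3 values shown sit. Compound 4 is therefore expected to give about 50000 nM in this assay, within a range from 20000 nM to 100000 nM, most probably reported as a limit.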

Compound 4, half-maximal inhibitory concentration: 36200 nM
Beside the measured number, compound 4's estimate is 1.4-fold (0.14 log units) above it; the measured number falls inside the stated range.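

In this assay, for the compounds shown here, 2,4-difluorophenyl on this aromatic carbon gives the first true number of the series, yet the change from phenyl amounts to an at least 1.3-fold lower number from compound 2 to compound 4 (0.14 log units; that floor lies within the scatter). The step therefore does not set compound 4 apart from compound 2, and this position shows no clear response to the change. The other results shown remain limits: the limit of > 50000 nM in this assay, at which 2 of the 4 values shown sit.

With no result for compound 3, the 4-chlorophenyl group offers no comparison. On these data alone, whether an amine or a carboxylic acid on this phenyl ring, or a longer chain in place of the acetyl group, would shift the value stays open.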